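A few compounds are considered here, and "the series" means these few. Any claim that something is new, unique, unknown or untested is made for them only; others in the source may bear on it.

Of the compounds shown here, three carrying the same lactone core have been measured in a functional assay on LUC1 cells (Homo sapiens) for cytotoxicity, read by sulforhodamine B assay, with a stated time of 48 h; a higher number here means that more compound is needed for the effect, a lower number that less compound is needed. Compound 1 `CCCC[C@@H](/C=C\[C@@H]1OC(=O)C=C[C@@H]1O)OC(C)=O` gives 2.3 ug/mL. Compound 2 `CCCC[C@H](OC(C)=O)[C@@H](OC(C)=O)[C@H](OC(C)=O)[C@H]1CC=CC(=O)O1`, whose side chain bears three acetoxy groups on a saturated chain, gives 3.9 ug/mL. Compound 3 `CCCC[C@@H](/C=C\[C@@H]1OC(=O)C=C[C@@H]1OC(C)=O)OC(C)=O` gives 0.9 ug/mL. Among these three numbers compound 2 shows the highest; the number of compound 1 lies within the scatter of it, so the two are not distinguished, whereas compound 3 sits clearly lower, beyond the scatter.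

For the measured compounds named here, one measured step bears on the move now followed. Placing acetyl in place of hydrogen on an oxygen on a saturated carbon gave a 2.6-fold lower number from compound 1 to compound 3 (0.41 log units; beyond the scatter), a modest lowering that nonetheless exceeds the scatter. Compound 4 `CCCC[C@H](OC(C)=O)[C@@H](OC(C)=O)[C@H](OC(C)=O)[C@@H]1OC(=O)C=C[C@@H]1OC(C)=O` arises from compound 2 by acetoxy in place of hydrogen on a saturated ring carbon. Although in compound 2 no hydroxyl stands at that ring position beforehand, the outcome is the same ring acetoxy that compound 3 carries, so the step from compound 1 to compound 3 is the closest guide available. Compound 4 is therefore expected to give a modestly lower number in this assay, by about a 2.2-fold lower number from compound 2 to compound 4 (0.34 log units; beyond the scatter). The estimated value of compound 4 is 1.8 ug/mL, with a plausible range from 0.8 ug/mL to 4 ug/mL.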

Compound 4, concentration for half-maximal effect: 7.6 ug/mL
Estimate against measurement, compound 4: 4.2-fold (0.63 log units) below; measured number above the stated range.
By their numbers in this assay, from the lowest: compound 3; then compounds 1, 2 and 4 (each within the scatter of the next, the first and the last beyond it).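

In this assay, acetoxy in place of hydrogen on a saturated ring carbon gives a 1.9-fold higher number from compound 2 to compound 4 (0.29 log units; within the scatter) and so does not separate compound 4 from compound 2. The ring acetoxy of compound 3 had come with a 2.6-fold lower number from compound 1 to compound 3 (0.41 log units; beyond the scatter) on the other side chain, but that step began from a ring hydroxyl and this one from a ring hydrogen, and no lowering beyond the scatter appears when the side chain bears three acetoxy groups. The earlier step therefore does not carry over to this pair: the two compounds with three acetoxy groups on the saturated chain stay within the scatter of each other whether or not the ring carbon bears acetoxy, though this rests on a single pair.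

The compounds shown leave open whether a free hydroxyl, a methoxy group or an amine on this ring carbon would separate from hydrogen or acetoxy when the side chain carries three acetoxy groups. Nothing measured here offers an explanation for why the two steps differ.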